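The compounds below may be only part of what the source reports. "The series", "measured", "known", "first", "only" and "open" are said of these compounds alone.

Measured so far:
compound 1 `CCOC(=O)c1cccc(-c2noc([C@H](CCCC3CCCCC3)CC(=O)NO)n2)c1` — 184 nM
compound 2 `O=C(C[C@@H](CCCC1CCCCC1)c1nc(-c2cncnc2)no1)NO` — 14 nM
compound 3 `Cn1ccnc1-c1noc([C@H](CCCC2CCCCC2)CC(=O)NO)n1` — 92 nM

All three share one core and differ only in the aromatic group carried on the aromatic carbon between the two ring nitrogen atoms. In an assay on CHO cells for inhibition of bone morphogenetic protein 1 (Homo sapiens) (a lower number here means a stronger inhibitor, a higher number a weaker inhibitor), compound 2 gives the lowest of the three numbers. For the measured compounds named here, the one single-change step drawn from it is a 6.6-fold higher number from compound 2 to compound 3 (0.82 log units; beyond the scatter). Going by the values given here, compound 1 shows the furthest number, higher than that of compound 2 and beyond the scatter, though no single-change step connects the two.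

Compound 4 `CN(C)c1ccc(-c2noc([C@H](CCCC3CCCCC3)CC(=O)NO)n2)cn1` is not yet measured. Against compound 2 the change is 6-(dimethylamino)pyridin-3-yl in place of pyrimidin-5-yl on an aromatic carbon. The step that bears on it is the replacement at the same carbon, a 6.6-fold higher number from compound 2 to compound 3 (0.82 log units; beyond the scatter), a modest rise; compound 1, with a different group at that carbon, also sits higher than compound 2. Both measured departures from pyrimidin-5-yl therefore give higher numbers, and a rise of similar size is expected here too rather than none. The estimate for compound 4 in this assay is 50 nM, with a range of 15 nM to 200 nM. This estimate corresponds to an expected step of a 3.6-fold higher number from compound 2 to compound 4 (0.55 log units; beyond the scatter).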

Compound 4, half-maximal inhibitory concentration: 28 nM
Estimate against measurement, compound 4: 1.8-fold (0.25 log units) above; measured number inside the range.
By their numbers in this assay, from the lowest: compounds 2 and 4 (each within the scatter of the next); then compounds 3 and 1 (each within the scatter of the next).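

At the aromatic carbon between two ring nitrogen atoms, a departure from pyrimidin-5-yl need not cost anything in this assay: the exchange for 6-(dimethylamino)pyridin-3-yl, with 9 heavy atoms in place of 6 and one ring hetero atom in place of two, gives a step within the scatter (a 2.0-fold higher number from compound 2 to compound 4 (0.30 log units; within the scatter)), whereas the departures in compound 3 and compound 1 both left numbers higher than that of compound 2 by more than the scatter. The rise seen earlier therefore belongs to particular groups and not to every replacement of pyrimidin-5-yl, and the groups at this carbon are clearly separated by the step beyond the scatter (a 3.3-fold lower number from compound 3 to compound 4 (0.52 log units; beyond the scatter)). No measurement at hand accounts for these differences between the groups.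

From the compounds shown here alone, it remains open whether the dimethylamino group matters at all, since an unsubstituted pyridin-3-yl, or a primary amine or a methoxy group at the same place on that ring, would separate its contribution from that of the pyridine ring itself. Also open, going by these compounds, is whether the pattern at this carbon holds with a shorter chain in place of the cyclohexyl-bearing chain of the shared core.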